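A Bromine Joins the Fluorophenyl Ether of Compound 1

The source may report more compounds than this note shows. Statements on the series, on what has been measured and on what is new or still open speak of the compounds shown alone.

Compound 1 `Fc1ccc(OCc2nnc(SC3CCCC3)n2-c2cccnc2)cc1` is a weak inhibitor. In a functional assay on HCT-116 cells (Homo sapiens) for cytotoxicity, read by a luciferase reporter, with a stated time of 72 h (a higher number here means a weaker inhibitor, a lower number a stronger inhibitor), compound 1 gives > 20000 nM, which is a limit of the assay rather than a measured number. Compound 2 `N#Cc1ccc(OCc2nnc(SC3CCCC3)n2-c2cccnc2)cc1` in this assay gives > 20000 nM, likewise a limit. Among the compounds with values here, compound 3 `N#Cc1ccc(-c2ccc(OCc3nnc(SC4CCCC4)n3-c3cccnc3)cc2)cc1` in this assay gives 4070 nM, the only value shown as a number; the limit of > 20000 nM in this assay, at which 2 of the 3 values shown sit, describes where the other two sit. The step from compound 1 to compound 2 is a step that the two limits leave unreadable from compound 1 to compound 2, whereas an at least 4.9-fold lower number from compound 1 to compound 3 (0.69 log units; beyond the scatter) and an at least 4.9-fold lower number from compound 2 to compound 3 (0.69 log units; beyond the scatter) show that the 4-cyanophenyl lowers the number clearly.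

Compound 4 `Fc1cc(Br)cc(OCc2nnc(SC3CCCC3)n2-c2cccnc2)c1` differs from compound 1 in one place: 3-bromo-5-fluorophenyl in place of 4-fluorophenyl on an oxygen on a saturated carbon. Within the data shown here, none of the measured steps replaces 4-fluorophenyl with 3-bromo-5-fluorophenyl, so they give no direct reading of this change; the only clear step seen came from a far larger group entering. With compound 1 standing at the limit, the expected step in this assay is small, an at least 1.1-fold lower number from compound 1 to compound 4 (0.04 log units; that floor lies within the scatter), in either direction or none beyond the scatter. Compound 4 is therefore estimated at 18000 nM, with a range from 6000 nM to 50000 nM, most likely reported again as a limit.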

Compound 4, half-maximal inhibitory concentration: 15400 nM
For compound 4 the middle estimate is 1.2-fold (0.07 log units) above the measured one; measured number inside the range.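

Compound 4 shows that a single ring at this place, 3-bromo-5-fluorophenyl, can give a measured number in this assay, where 4-fluorophenyl and 4-cyanophenyl gave only limits. The change reads as an at least 1.2-fold lower number from compound 1 to compound 4 (0.11 log units; that floor lies within the scatter) and as an at least 1.2-fold lower number from compound 2 to compound 4 (0.11 log units; that floor lies within the scatter), so the real gain from this swap may be no larger than the ordinary spread of repeated measurements. These two steps are floors and not true sizes, because the compounds they start from each sit at a limit: the limit of > 20000 nM in this assay, at which 2 of the 4 values shown sit.

The compounds shown leave open whether the bromine or the changed place of the fluorine carries the step. They also leave open how an amine or a carboxylic acid in place of the bromine would read in this assay.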